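Ring swap on the chain carbon of compound 1

The source may report more compounds than this note shows. Statements on the series, on what has been measured and on what is new or still open speak of the compounds shown alone.

Compound 1 `CC(C)C(Cc1ncc[nH]1)c1ccc(-c2ccc3cccc(F)c3c2)[nH]c1=O` carries a 1H-imidazol-2-yl group on a saturated chain carbon. For the measured compounds named here, in an ADME assay on microsomes from liver (Homo sapiens) for metabolic stability (a lower number here means that the compound disappears faster, a higher number that the compound lasts longer), compound 1 gives 0.106 h, the lowest of the three numbers measured so far. Compound 2 `CC(C)[C@H](C[C@H]1CCNC1=O)c1ccc(-c2ccc3cccc(F)c3c2)[nH]c1=O` gives 0.257 h in this assay, and compound 3 `CC(C)[C@@H](C[C@H]1CCNC1=O)c1ccc(-c2ccc3cccc(F)c3c2)[nH]c1=O` gives 0.693 h. The step of a 2.7-fold higher number from compound 2 to compound 3 (0.43 log units; beyond the scatter) rests on configuration alone, given (the fact that compounds 2 and 3 differ only in the configuration as drawn), so configuration by itself moves the half-life here by a modest amount.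

Compound 4 `CC(C)C(Cc1noc(=O)[nH]1)c1ccc(-c2ccc3cccc(F)c3c2)[nH]c1=O` differs from compound 1 by a group of 6 heavy atoms (2 carbon, 2 nitrogen, 2 oxygen; one five-membered aromatic ring with 3 hetero atoms) in place of a group of 5 heavy atoms (3 carbon, 2 nitrogen; one five-membered aromatic ring with 2 hetero atoms), on a saturated chain carbon, two bonds along the chain from an aromatic carbon. Going by the values given here, none of the measured steps touches the ring on this chain carbon: the one measured step, from compound 2 to compound 3, concerns configuration only and offers no guide to a swap of ring type. The expectation for compound 4 in this assay therefore rests on compound 1 alone, and no direction beyond the scatter is called for. Compound 4 is estimated at 0.15 h, within 0.06 h to 0.4 h. The expected step of a 1.4-fold higher number from compound 1 to compound 4 (0.15 log units; within the scatter) is thus set close to no change, with the range kept wide to cover either direction.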

Compound 4, half-life: > 3 h
Compound 4 ended at the assay's limit; the forecaster's own chance of this, stated with the estimate: 5%; at least 20-fold (1.30 log units) between middle value and limit.
By their numbers in this assay, from the lowest: compound 1; then compound 2; then compound 3. At a limit, above all of these: compound 4.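

On the saturated chain carbon, two bonds along the chain from an aromatic carbon, ring type turns out to be a strong lever on the half-life in this assay: with a five-membered aromatic ring with 3 hetero atoms entering in place of 1H-imidazol-2-yl, the change gives an at least 28-fold higher number from compound 1 to compound 4 (1.45 log units; beyond the scatter). That step is larger than the modest 2.7-fold higher number from compound 2 to compound 3 (0.43 log units; beyond the scatter), so within the compounds shown a ring swap at this place counts for more than configuration, although this rests on a single pair with the core of compound 1 unchanged. Compound 4 gives > 3 h, which is a limit of the assay and not a number, so the full size of the step cannot be stated: the limit of > 3 h in this assay, at which 1 of the 4 values shown sits.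

Which feature of the entering ring carries the step stays open, since the carbonyl and the changed hetero atoms arrive together in one change and a single pair cannot separate them. Also open, going by these compounds, is whether a carboxylic acid or a primary amine on the same chain carbon would stand nearer compound 1 or compound 4, and how the configuration at that carbon, undrawn in both compounds, bears on the half-life.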